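From pent-1-en-1-yl to chloromethyl on the carbonyl carbon

The compounds below may be only part of what the source reports. "The series", "measured", "known", "first", "only" and "open" are said of these compounds alone.

Measured in a functional assay on MGC-803 cells (Homo sapiens) for inhibition, read by MTT assay, with a stated time of 48 h; a lower number here means a stronger inhibitor, a higher number a weaker inhibitor:
compound 1 `C#CC(=O)N(Cc1ccc(OC)c(O)c1)c1cc(OC)c(OC)c(OC)c1`: 170 nM
compound 2 `CCC/C=C/C(=O)N(Cc1ccc(OC)c(O)c1)c1cc(OC)c(OC)c(OC)c1`: 70 nM

Of these two compounds, compound 2 has the lower number at 70 nM, which makes it the stronger inhibitor. Compound 3 `COc1ccc(CN(C(=O)CCl)c2cc(OC)c(OC)c(OC)c2)cc1O` keeps the shared core but differs at one place: chloromethyl in place of pent-1-en-1-yl on a carbonyl carbon. For the measured compounds named here, only one measured step bears on this change: a 2.4-fold lower number from compound 1 to compound 2 (0.39 log units; beyond the scatter), a modest step at the same kind of carbonyl carbon. Going by the values given here, no measured compound yet carries chloromethyl, so the reading is loose. A similarly modest rise is expected, with an estimated 2.6-fold higher number from compound 2 to compound 3 (0.41 log units; beyond the scatter). In this assay, compound 3 is estimated at 180 nM, with an expected range of 50 nM to 650 nM.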

Compound 3, half-maximal inhibitory concentration: 84 nM
Compound 3: middle estimate off by 2.1-fold (0.33 log units), on the high side, within the range that was stated.
By their numbers in this assay, from the lowest: compounds 2 and 3 (each within the scatter of the next); then compound 1.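

In this assay, chloromethyl in place of pent-1-en-1-yl on the carbonyl carbon gives a 1.2-fold higher number from compound 2 to compound 3 (0.08 log units; within the scatter), so these two quite different groups cannot be told apart at this position. Chloromethyl in place of ethynyl gives a 2.0-fold lower number from compound 1 to compound 3 (0.31 log units; beyond the scatter), which means that two groups, not pent-1-en-1-yl alone, now stand apart from ethynyl here. Nothing available explains why these groups read as they do. The compounds shown leave open how a plain methyl, a bromomethyl or an amine on the carbonyl carbon would read in this assay.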